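Trimethoxy extension of the dimethoxyphenyl pyrazoline

The source may hold more compounds than are shown below. What is called first, only, known or untested is meant among the compounds shown, and "the series" means these compounds.

Three pyrazolines of one shared core have been measured in a functional assay on SF-295 cells (Homo sapiens) for antiproliferative activity, with a stated time of 48 h; a higher number here means that more compound is tolerated, a lower number that less compound is tolerated. Compound 1 `Cc1cc(O)c(C2=NN(c3ccc(S(N)(=O)=O)cc3)C(c3ccccc3Cl)C2)cc1Cl` gives 6340 nM, compound 2 `Cc1cc(O)c(C2=NN(c3ccc(S(N)(=O)=O)cc3)C(/C=C/c3ccccc3)C2)cc1Cl` gives 37300 nM, and compound 3 `COc1ccc(C2CC(c3cc(Cl)c(C)cc3O)=NN2c2ccc(S(N)(=O)=O)cc2)cc1OC` gives 340 nM. Compound 3 shows the lowest number of the three: a 19-fold lower number from compound 1 to compound 3 (1.27 log units; beyond the scatter), and a 110-fold lower number from compound 2 to compound 3 (2.04 log units; beyond the scatter). Among the compounds with values here, the one larger step in the other direction, a 5.9-fold higher number from compound 1 to compound 2 (0.77 log units; beyond the scatter), does not touch the methoxy-bearing ring.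

Compound 4 `COc1ccc(C2CC(c3cc(Cl)c(C)cc3O)=NN2c2ccc(S(N)(=O)=O)cc2)c(OC)c1OC` carries one more group on that ring: methoxy in place of hydrogen on an aromatic carbon. Within the data shown here, no measured pair of the series probes the addition of a single methoxy group; the two steps ending at compound 3 compare whole aryl groups and say nothing about a third methoxy on the same ring. On this basis the step of a 1.3-fold higher number from compound 3 to compound 4 (0.12 log units; within the scatter) is expected to stay within the scatter, with no clear direction. Compound 4 is estimated at 450 nM, with a range from 150 nM to 1500 nM.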

Compound 4, concentration lethal to 50% of the cells: 8700 nM
Compound 4: middle estimate off by 19-fold (1.29 log units), on the low side; measured number above the stated range.
By their numbers in this assay, from the lowest: compound 3; then compounds 1 and 4 (each within the scatter of the next); then compound 2.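

In this assay, within the data shown here, the series now has its only step of a single added group, and it is not neutral: a methoxy group on the aromatic carbon ortho to a large group and ortho to a methoxy group gives (a 26-fold higher number from compound 3 to compound 4 (1.41 log units; beyond the scatter)). The low number of compound 3 therefore belongs to the 3,4-dimethoxyphenyl group and does not extend to the 2,3,4-trimethoxyphenyl group, which remains clear of the 2-phenylethenyl group (a 4.3-fold lower number from compound 2 to compound 4 (0.63 log units; beyond the scatter)) but is not separated from the 2-chlorophenyl group (a 1.4-fold higher number from compound 1 to compound 4 (0.14 log units; within the scatter)). No evidence at hand bears on why this single methoxy group has so large a consequence.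

Going by these compounds, whether any group on this aromatic carbon would give the same rise or whether it is particular to methoxy stays open, for instance with a fluorine atom, a hydroxy group or an ethoxy group. Also open, on these data alone, is whether a third methoxy group elsewhere on the ring, as in a 3,4,5-trimethoxyphenyl group, would behave the same way.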